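Swapping a Hydrogen for 3-Methoxyphenyl on the Ring Nitrogen

This account rests on a few compounds, and the source may have more. Where it says the series, first, only, none or still open, it means among the compounds named here.

In a functional assay on HCT-116 cells (Homo sapiens) for antiproliferative activity, read by MTT assay, with a stated time of 72 h (on this read-out higher numbers stand for weaker inhibition and lower numbers for stronger inhibition), compound 2 `COc1ncc(-c2ccc3c(c2)NC(=O)CO3)cc1NS(=O)(=O)c1ccc(F)cc1` gives 24900 nM. For the measured compounds named here, its only measured neighbour, compound 1 `COc1ncc(-c2ccc3c(c2)N(c2ccc(C)cc2)C(=O)CO3)cc1NS(=O)(=O)c1ccc(F)cc1`, gives 22700 nM, so the two numbers cannot be told apart within the usual scatter. The unmeasured compound 3 `COc1cccc(N2C(=O)COc3ccc(-c4cnc(OC)c(NS(=O)(=O)c5ccc(F)cc5)c4)cc32)c1` differs from compound 2 in one place: 3-methoxyphenyl in place of hydrogen on an amide-type nitrogen in a ring. In words, 3-methoxyphenyl stands in place of hydrogen on an amide-type nitrogen in a ring. Going by the values given here, one measured step bears on this change: hydrogen in place of 4-methylphenyl at that same nitrogen gave a 1.1-fold higher number from compound 1 to compound 2 (0.04 log units; within the scatter). On that single step, no change beyond the scatter is expected in this assay, although a different group is entering here, so the range stays wide. The estimated step is a 1.2-fold lower number from compound 2 to compound 3 (0.10 log units; within the scatter). Compound 3 is expected at about 20000 nM, with an estimated range of 9000 nM to 40000 nM.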

Compound 3, half-maximal inhibitory concentration: > 40000 nM
Compound 3 was reported as a limit (the forecaster's own chance of this, stated with the estimate: 10%); middle value at least 2.0-fold (0.30 log units) from the limit.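

Compound 3 is reported only as a limit of the assay, not as a number, in this assay: the limit of > 40000 nM in this assay, at which 1 of the 3 values shown sits.

For the compounds shown here, this gives the first sign that the group on this ring nitrogen might matter, since hydrogen and 4-methylphenyl could not be told apart. Placing 3-methoxyphenyl on the nitrogen gives an at least 1.6-fold higher number from compound 2 to compound 3 (0.20 log units; that floor lies within the scatter), and exchanging 4-methylphenyl for it gives an at least 1.7-fold higher number from compound 1 to compound 3 (0.24 log units; that floor lies within the scatter). From the compounds shown here alone, both figures are floors inside the usual scatter, so they show no firm loss of activity, and the true size of either step stays unknown.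

The compounds shown leave open where the true number for compound 3 lies. They also leave open how this nitrogen would respond to a small methyl group, to 4-methoxyphenyl, or to a chain ending in an amine.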